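The compounds below may be only part of what the source reports. "The series", "measured", "known", "first", "only" and "open" are said of these compounds alone.

Of the compounds shown here, three built on one shared core have been measured in a functional assay on M21 cells (Homo sapiens) for antiproliferative activity, read by sulforhodamine B assay, with a stated time of 48 h; on this read-out lower numbers stand for stronger inhibition and higher numbers for weaker inhibition. Compound 1 `CCc1ccccc1NS(=O)(=O)c1ccc(N2CCNC2=O)cc1` gives 180 nM, compound 2 `COc1ccc(NS(=O)(=O)c2ccc(N3CCNC3=O)cc2)cc1` gives 580 nM, and compound 3 `Cc1ccc(C)c(NS(=O)(=O)c2ccc(N3CCNC3=O)cc2)c1` gives 27 nM. Compound 2 thus holds the highest number of the three, meaning the weakest inhibition: there is a 3.2-fold higher number from compound 1 to compound 2 (0.51 log units; beyond the scatter) and a 21-fold lower number from compound 2 to compound 3 (1.33 log units; beyond the scatter).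

Compound 4 `CCCCCCCc1ccc(NS(=O)(=O)c2ccc(N3CCNC3=O)cc2)cc1` differs from compound 2 in a single place: heptyl in place of methoxy on an aromatic carbon. For the measured compounds named here, none of the measured steps exchanges one group for another at this same place; the two steps touching compound 2 instead swap the whole substituted ring, and both end at lower numbers away from compound 2. Going by the values given here, the measured set holds no compound carrying a plain chain of this length, so the direction of the change is uncertain. Given that compound 2 sits at the weak end, a modest move toward lower numbers seems somewhat more likely than a further rise, but a step within the scatter would not be surprising. Compound 4 is therefore expected to give about 350 nM, with a range from 90 nM to 1500 nM. That estimate corresponds to an expected step of a 1.7-fold lower number from compound 2 to compound 4 (0.22 log units; within the scatter).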

Compound 4, half-maximal inhibitory concentration: > 1000 nM
Compound 4: no number, only a limit; the forecaster's own chance of this, stated with the estimate: 5%; middle value at least 2.8-fold (0.45 log units) away from the limit.
By their numbers in this assay, from the lowest: compound 3; then compound 1; then compound 2. At a limit, above all of these: compound 4.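

In this assay compound 4 gives > 1000 nM, which is a limit of the assay and not a number. This is the first exchange shown at the aromatic carbon para to a large group, and it reads as an at least 1.7-fold higher number from compound 2 to compound 4 (0.23 log units; that floor lies within the scatter), so heptyl in place of methoxy brought no lower number here, unlike the two ring swaps that lead away from compound 2. Only a floor is known for this step, and its true size cannot be read: the limit of > 1000 nM in this assay, at which 1 of the 4 values shown sits.

With just methoxy and heptyl shown at this place, no trend with chain length can be drawn. Going by these compounds, it stays open whether a shorter chain such as propyl, or a polar group such as an amine or a carboxylic acid, would give a lower number than compound 2 does.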